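Cytotoxicity of bridged amines: swapping a cinnamate ester

The source may hold more compounds than are shown below. What is called first, only, known or untested is meant among the compounds shown, and "the series" means these compounds.

Compound 2 `CN(C)C12CC(OC(=O)/C=C/c3ccccc3)C(C(c3ccccc3)C1)C(c1ccccc1)C2` gives 3820 nM in an ADME assay on L6 cells (Rattus norvegicus) for cytotoxicity, with a stated time of 72 h; on this read-out lower numbers stand for stronger inhibition and higher numbers for weaker inhibition. Compound 1 `CN(C)C12CC(OC(=O)CN3CCCC3)C(C(c3ccccc3)C1)C(c1ccccc1)C2` carries (pyrrolidin-1-yl)methyl in place of 2-phenylethenyl on a carbonyl carbon, and in this assay compound 1 gives 32700 nM, so this change produced an 8.6-fold higher number from compound 2 to compound 1 (0.93 log units; beyond the scatter). Compound 3 `O=C(/C=C/c1ccccc1)OC1CC2(N3CCCCC3)CC(c3ccccc3)C1C(c1ccccc1)C2` differs from compound 2 in its core by piperidin-1-yl in place of dimethylamino on a saturated ring carbon; in this assay compound 3 gives 10500 nM, a step of a 2.7-fold higher number from compound 2 to compound 3 (0.44 log units; beyond the scatter). Within the data shown here, compound 4 `O=C(CN1CCCC1)OC1CC2(N3CCCCC3)CC(c3ccccc3)C1C(c1ccccc1)C2` is not yet measured; it differs from compound 3 by (pyrrolidin-1-yl)methyl in place of 2-phenylethenyl on a carbonyl carbon, the same change as the one from compound 2 to compound 1, made at the same place. Because that earlier change gave an 8.6-fold higher number from compound 2 to compound 1 (0.93 log units; beyond the scatter), a step of about the same size is expected here, namely a 7.6-fold higher number from compound 3 to compound 4 (0.88 log units; beyond the scatter). For compound 4 the expected value in this assay is 80000 nM, with a likely range from 30000 nM to 200000 nM.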

Compound 4, half-maximal inhibitory concentration: 16400 nM
Beside the measured number, compound 4's estimate is 4.9-fold (0.69 log units) above it; the whole stated range lies above it.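

On the core carrying piperidin-1-yl, (pyrrolidin-1-yl)methyl in place of 2-phenylethenyl on a carbonyl carbon gives a 1.6-fold higher number from compound 3 to compound 4 (0.19 log units; within the scatter) in this assay, so the size of this step did not carry over from the core carrying dimethylamino: the same change on two cores in this assay, an 8.6-fold higher number (0.93 log units; beyond the scatter) from compound 2 to compound 1 and a 1.6-fold higher number (0.19 log units; within the scatter) from compound 3 to compound 4, 5.5-fold (0.74 log units) apart, beyond the scatter of two such steps. Likewise, piperidin-1-yl in place of dimethylamino on a saturated ring carbon gives a 2.0-fold lower number from compound 1 to compound 4 (0.30 log units; within the scatter) when the ester carries (pyrrolidin-1-yl)methyl, and this step does not match its earlier counterpart: the same change on two cores in this assay, a 2.7-fold higher number (0.44 log units; beyond the scatter) from compound 2 to compound 3 and a 2.0-fold lower number (0.30 log units; within the scatter) from compound 1 to compound 4, 5.5-fold (0.74 log units) apart, beyond the scatter of two such steps. In these four compounds the two changes therefore do not act independently, but the data show neither why nor how either change would behave on any other core.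

On these data alone, it remains open whether a different group on the carbonyl carbon, such as (morpholin-4-yl)methyl or a longer chain ending in an amine, would follow the same pattern. As far as these compounds go, it is also open whether a pyrrolidin-1-yl group on the saturated ring carbon would do so.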